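Sulfonyl aryl variation on the shared core

The compounds below may be only part of what the source reports. "The series", "measured", "known", "first", "only" and "open" are said of these compounds alone.

Compound 1 `Cc1noc(C)c1S(=O)(=O)N1CCC(N2CCC(C)CC2)CC1` carries 3,5-dimethyl-1,2-oxazol-4-yl on the sulfonyl sulfur. In a functional assay on DLD-1 cells (Homo sapiens) for antiproliferative activity, read by CellTiter-Glo, with a stated time of 72 h (a higher number here means a weaker inhibitor, a lower number a stronger inhibitor), compound 1 gives > 5000 nM, which is a limit of the assay and not a number. Compound 1 therefore stands at the limit of > 5000 nM in this assay, at which 1 of the 3 values shown sits. The two other measured compounds lie well inside the measurable range: compound 2 `CC1CCN(C2CCN(S(=O)(=O)c3cccc(-c4ccc(F)cc4)c3)CC2)CC1` gives 12 nM in this assay, and compound 3 `Cc1cc(C)c(S(=O)(=O)N2CCC(N3CCC(C)CC3)CC2)c(C)c1` gives 0.03 nM. Both carry a carbon-only aromatic ring on the sulfonyl sulfur; with two examples no general rule is claimed.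

Compound 4 `CC1CCN(C2CCN(S(=O)(=O)c3ccc(C#N)cc3)CC2)CC1` remains to be measured in this assay. It differs from compound 1 as follows: 4-cyanophenyl in place of 3,5-dimethyl-1,2-oxazol-4-yl on a sulfonyl sulfur. Within the data shown here, no measured step of this kind exists on the core. Given the values of compound 2 and compound 3 and the limit of compound 1, a step toward stronger inhibition, beyond the scatter, is expected, though 4-cyanophenyl appears in no measured compound. For compound 4 the expected step is an at least 83-fold lower number from compound 1 to compound 4 (1.92 log units; beyond the scatter). Compound 4 is estimated at 60 nM, with a range from 5 nM to 800 nM.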

Compound 4, half-maximal inhibitory concentration: 2800 nM
Compound 4: middle estimate off by 47-fold (1.67 log units), on the low side; the measured number lies above the stated range.
By their numbers in this assay, from the lowest: compound 3; then compound 2; then compound 4. At a limit, above all of these: compound 1.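

In this assay, 4-cyanophenyl in place of 3,5-dimethyl-1,2-oxazol-4-yl on a sulfonyl sulfur gives an at least 1.7-fold lower number from compound 1 to compound 4 (0.25 log units; that floor lies within the scatter). A carbon-only aromatic ring on the sulfonyl sulfur does not by itself secure a low number on the shared core: compound 4 carries one and gives 2800 nM, whereas compound 2 gives 12 nM and compound 3 gives 0.03 nM. The value of compound 1 is a limit of the assay, and the true size of this step cannot be read because of it: the limit of > 5000 nM in this assay, at which 1 of the 4 values shown sits.

From the compounds shown here alone, it remains open whether the nitrile goes with the weak value of compound 4 or whether the aryl ring as a whole does. Plain phenyl and 4-aminophenyl on the same sulfonyl sulfur would test this on the shared core.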